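Series notes: stability step from compound 2 to compound 3

A few compounds are considered here, and "the series" means these few. Any claim that something is new, unique, unknown or untested is made for them only; others in the source may bear on it.

Compound 2 `Nc1ccc(S(=O)(=O)N2CCN(c3ncc(C(O)(C(F)(F)F)C(F)(F)F)cc3-c3cccc(F)c3)CC2)cn1` and compound 1 `Nc1ccc(S(=O)(=O)N2CCN(c3ncc(C(O)(C(F)(F)F)C(F)(F)F)cc3C3CC3)CC2)cn1` share a core and differ only in one group. In an ADME assay (liver) for metabolic stability, with Liver microsome (Homo sapiens) as the target, using microsomes and NADPH, with a stated time of 30 min, tested at 1 uM (on this read-out lower numbers stand for slow clearance and higher numbers for fast clearance), compound 1 gives 38 mL.min-1.g-1 and compound 2 gives 25 mL.min-1.g-1; the step of a 1.5-fold lower number from compound 1 to compound 2 (0.18 log units; within the scatter) lies within the scatter, so the two stand as equals. Compound 3 `Nc1ccc(S(=O)(=O)N2CCN(c3ncc(C(O)(C(F)(F)F)C(F)(F)F)cc3-c3ccc4c(c3)CC(=O)N4)CC2)cn1` carries a group of 10 heavy atoms (8 carbon, 1 nitrogen, 1 oxygen; one five-membered non-aromatic ring with 1 hetero atom, one six-membered aromatic ring of carbon only) in place of a group of 7 heavy atoms (6 carbon, 1 fluorine; one six-membered aromatic ring of carbon only), on an aromatic carbon. Going by the values given here, no measured step bears on this kind of change; the one available step is within the scatter. Compound 3 is therefore expected to give 25 mL.min-1.g-1 (range 12 mL.min-1.g-1 to 50 mL.min-1.g-1), a step of no change at the digits printed from compound 2 to compound 3 (within the scatter) that is expected to stay within the scatter.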

Compound 3, intrinsic clearance in microsomes: < 14 mL.min-1.g-1
Compound 3 was reported as a limit; the forecaster's own chance of this, stated with the estimate: 5%; at least 1.7-fold (0.25 log units) between middle value and limit.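

Compound 3 is reported in this assay as a limit, not a number: the limit of < 14 mL.min-1.g-1 in this assay, at which 1 of the 3 values shown sits.
Going by these compounds alone, the change from cyclopropyl gives an at least 2.7-fold lower number from compound 1 to compound 3 (0.43 log units; beyond the scatter) and is the first step at this position to lie beyond the scatter. The change from 3-fluorophenyl gives an at least 1.7-fold lower number from compound 2 to compound 3 (0.25 log units; that floor lies within the scatter) and so does not yet separate the entering group from 3-fluorophenyl.

Going by these compounds, the true size of both steps stays open, as the limit sets only their floor. Also open, on these data alone, is whether a phenyl group carrying an amine or a carboxylic acid at this position would read the same way.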